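This account rests on a few compounds, and the source may have more. Where it says the series, first, only, none or still open, it means among the compounds named here.

Of the compounds shown here, three built on a shared core have been tested in a functional assay on MCF7 cells (Homo sapiens) for cytotoxicity, read by MTT assay, with a stated time of 72 h, tested at 10 uM; on this read-out higher numbers stand for more inhibition of growth at the one concentration tested and lower numbers for less inhibition of growth. Compound 1 `N/C(=N\NC(=S)N1CCSCC1)c1ccccn1` gives 54.3%, compound 2 `Cc1cccc(/C(N)=N/NC(=S)N2CCCCC2)n1` gives 39%, and compound 3 `N/C(=N\NC(=S)N1CCOCC1)c1ccc(F)cn1` gives 39.5%. Among these three numbers compound 3 stands second highest: compound 2 lies within the usual scatter of it, while compound 1 lies above it by more than the scatter. Compound 4 `N/C(=N\NC(=S)N1CCOCC1)c1ccccn1` differs from compound 3 by hydrogen in place of fluoro on an aromatic carbon. Among the compounds with values here, no two measured compounds differ at this one place alone, so the size of the step in this assay is not known from the data; a small step, if any, is expected, leaning toward more inhibition. Compound 4 is therefore expected to give about 45% in this assay, within 30% to 60%, which amounts to an expected step of a number 5.5 percentage points higher from compound 3 to compound 4 (within the scatter).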

Compound 4, percent growth inhibition at one concentration: 66.7%
Compound 4: middle estimate off by 21.7 percentage points, on the low side; the whole stated range lies below it.
By their numbers in this assay, from the lowest: compounds 2 and 3 (each within the scatter of the next); then compound 1; then compound 4.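

In this assay, within the data shown here, hydrogen in place of fluoro on the aromatic carbon gives a number 27.2 percentage points higher from compound 3 to compound 4 (beyond the scatter) and so shows that this position is sensitive to what it carries, which no earlier pair could reveal. Morpholin-4-yl in place of thiomorpholin-4-yl on the thiocarbonyl carbon gives a number 12.4 percentage points higher from compound 1 to compound 4 (beyond the scatter) as well, so the group at that second place also matters. No measurement at hand accounts for either step. Open remains how chloro, methoxy or an amine would fare at the aromatic position, and whether the fluoro step would hold with thiomorpholin-4-yl.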